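The compounds below may be only part of what the source reports. "The series", "measured", "known", "first", "only" and "open" are said of these compounds alone.

Measured so far:
Compound 1, `CC1=CC[C@H](C(C)C)c2cc(C)c(OC(=O)c3ccccc3)cc21`: 60.7%
Compound 2, `CC1=CC[C@H](C(C)C)c2cc(C)c(OC(=O)c3cccc(Cl)c3)cc21`: 40.4%
Compound 3, `CC1=CC[C@H](C(C)C)c2cc(C)c(OC(=O)c3cccc(C)c3)cc21`: 54.9%

The three compounds share one core and differ only in the substituent on the benzoate ring. In a functional assay on MCF7 cells (Homo sapiens) for antiproliferative activity, read by sulforhodamine B assay, with a stated time of 48 h, tested at 50 uM (on this read-out higher numbers stand for more inhibition at the one concentration tested (going by the name of the read-out) and lower numbers for less inhibition), compound 1 gives 60.7%, compound 2 gives 40.4% and compound 3 gives 54.9%. Compound 3 stands second of the three numbers; the step of a number 5.8 percentage points lower from compound 1 to compound 3 (within the scatter) lies within the scatter, while the step of a number 14.5 percentage points higher from compound 2 to compound 3 (beyond the scatter) lies beyond it.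

Compound 4, `CC1=CC[C@H](C(C)C)c2cc(C)c(OC(=O)c3cccc([N+](=O)[O-])c3)cc21`, has not yet been measured. It differs from compound 3 by nitro in place of methyl on an aromatic carbon.

Among the compounds with values here, two measured steps bear on this change, since both swap the substituent at the same aromatic carbon. Replacing hydrogen by chloro gave a number 20.3 percentage points lower from compound 1 to compound 2 (beyond the scatter), a modest loss, whereas replacing hydrogen by methyl gave a number 5.8 percentage points lower from compound 1 to compound 3 (within the scatter), within the scatter. Going from chloro to methyl recovered a number 14.5 percentage points higher from compound 2 to compound 3 (beyond the scatter). A nitro group is thus entering where methyl behaved like hydrogen and chloro lowered the number. Compound 4 is therefore expected to show a modest downward step of a number 12.9 percentage points lower from compound 3 to compound 4 (beyond the scatter) in this assay. Compound 4 is estimated at 42%, with a range from 25% to 60%.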

Compound 4, a percentage reported as inhibition, at one concentration (the size of the read-out at that concentration, not a potency): 29.3%
Beside the measured number, compound 4's estimate is 12.7 percentage points above it; low and high end bracket the measured number.
By their numbers in this assay, from the lowest: compound 4; then compound 2; then compounds 3 and 1 (each within the scatter of the next).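

In this assay, putting nitro in place of methyl on this aromatic carbon gave a number 25.6 percentage points lower from compound 3 to compound 4 (beyond the scatter), and nitro in place of hydrogen gave a number 31.4 percentage points lower from compound 1 to compound 4 (beyond the scatter), the only step among these compounds graded as large. Nitro also went past chloro, with a number 11.1 percentage points lower from compound 2 to compound 4 (beyond the scatter), so the position now separates three levels instead of two: hydrogen and methyl, within the scatter of each other, then chloro, then nitro. The earlier compounds shown here showed only that one substituent here could lower the number, whereas compound 4 shows that the loss at this carbon can go further, though nothing measured on hand tells what sets this order.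

The compounds shown leave open where an amine, a methoxy group or a carboxylic acid at this carbon would fall on that scale, and whether any group here could raise the number over that of the unsubstituted benzoate. They also leave open whether chloro, methyl or nitro would give steps of the same size on another carbon of the same aromatic ring, as all three sit at a single place.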